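Swapping an Acetamide for a Methylpiperidine on a Shared Core

A few compounds are considered here, and "the series" means these few. Any claim that something is new, unique, unknown or untested is made for them only; others in the source may bear on it.

Measured compounds:
- Compound 1 `Cc1cn(-c2ccc(Nc3nccc(-c4ccncc4)n3)cc2)cn1`: in a functional assay for inhibition, with Homo sapiens as the target (on this read-out higher numbers stand for weaker inhibition and lower numbers for stronger inhibition), compound 1 gives only a limit of the assay, > 3000 nM.
- Compound 2 `CC(=O)N(C)c1ccc(Nc2nccc(-c3ccncc3)n2)cc1`: in this assay compound 2 gives 500 nM.

Among the compounds with values here, compound 2 holds the only true number in this assay; the other value is a limit of the assay (the limit of > 3000 nM in this assay, at which 1 of the 2 values shown sits). Compound 3 `CC1CCN(c2ccc(Nc3nccc(-c4ccncc4)n3)cc2)CC1` has not yet been measured and differs from compound 2 in one place: 4-methylpiperidin-1-yl in place of acetyl(methyl)amino on an aromatic carbon. Within the data shown here, the single measured step, an at least 6.0-fold lower number from compound 1 to compound 2 (0.77 log units; beyond the scatter), involves a different exchange on the same aromatic carbon and so bears only loosely on this one. It shows that this position tolerates change and can move the number, but it gives no direction for a non-aromatic ring. The expected change, a 1.2-fold higher number from compound 2 to compound 3 (0.08 log units; within the scatter), is therefore a small one, within the scatter, in either direction. Compound 3 is estimated at 600 nM, with a likely range from 150 nM to 3000 nM.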

Compound 3, half-maximal inhibitory concentration: 600 nM
Beside the measured number, compound 3's estimate shows no gap at the digits printed; low and high end bracket the measured number.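

In this assay, a 1.2-fold higher number from compound 2 to compound 3 (0.08 log units; within the scatter) shows that this aromatic carbon accepts a six-membered non-aromatic ring as readily as the open acetyl(methyl)amino group, despite the ring's larger heavy-atom count. The second step, an at least 5.0-fold lower number from compound 1 to compound 3 (0.69 log units; beyond the scatter), shows that the 4-methyl-1H-imidazol-1-yl group of compound 1 stands apart from both of the other groups, not just from acetyl(methyl)amino. The size of that gap remains unknown, since compound 1 provides only a limit and the step gives just a minimum: the limit of > 3000 nM in this assay, at which 1 of the 3 values shown sits.

Still open, as far as these compounds go, is whether a piperidine ring without its methyl group, or a morpholine ring, would fit in with compound 2 and compound 3. From the compounds shown here alone, it is equally open how a primary amine or a carboxylic acid on this carbon would read.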